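Fluorine on the Isopropyl Tail: Two Contexts Compared

The source may hold more compounds than are shown below. What is called first, only, known or untested is meant among the compounds shown, and "the series" means these compounds.

Of the compounds shown here, three sharing one core have been measured in a functional assay on isolated protein for inhibition of Glucose-dependent insulinotropic receptor (Homo sapiens), read by HTRF and cAMP accumulation; a lower number here means that less compound is needed, a higher number that more compound is needed for the effect. Compound 1 `Cc1nc(S(C)(=O)=O)ccc1Oc1ncnc(OC2CCN(C(=O)OC(C)C)CC2)c1F` gives 21 nM. Compound 2 `Cc1nc(S(C)(=O)=O)ccc1Oc1ncnc(OC2CCN(C(=O)O[C@@H](C)CF)CC2)c1F` carries the change fluoro in place of hydrogen on a saturated chain carbon, two bonds along the chain from an oxygen next to a carbonyl group and gives 186 nM, so that the step of an 8.9-fold higher number from compound 1 to compound 2 (0.95 log units; beyond the scatter) is recorded. Compound 3 `Cc1nc(S(C)(=O)=O)ccc1Oc1ncnc(OC2CCN(C(=O)c3noc(C(C)C)n3)CC2)c1F` differs from compound 1 by 5-isopropyl-1,2,4-oxadiazol-3-yl in place of isopropoxy on a carbonyl carbon. In this assay compound 3 gives 21.2 nM; the step of a 1.0-fold higher number from compound 1 to compound 3 (0.00 log units; within the scatter) shows that the two are indistinguishable here, while an 8.8-fold lower number from compound 2 to compound 3 (0.94 log units; beyond the scatter) mirrors the loss seen with the fluorinated carbamate.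

Compound 4 `Cc1nc(S(C)(=O)=O)ccc1Oc1ncnc(OC2CCN(C(=O)c3noc(C(C)(C)F)n3)CC2)c1F` has not been measured. It differs from compound 3 by fluoro in place of hydrogen on a saturated chain carbon bound to an aromatic carbon and two saturated chain carbons. This is the same kind of change as the one from compound 1 to compound 2, and it occurs two times among the compounds shown, but the surroundings differ: in compound 2 the fluoro sits on a saturated chain carbon, two bonds along the chain from an oxygen next to a carbonyl group, whereas in compound 4 it sits on a saturated chain carbon bound to an aromatic carbon and two saturated chain carbons.

Going by the values given here, the only precedent is compound 1 to compound 2, so compound 4 is expected to lose some potency, with a step of a 2.8-fold higher number from compound 3 to compound 4 (0.45 log units; beyond the scatter) in this assay, because an 8.9-fold higher number from compound 1 to compound 2 (0.95 log units; beyond the scatter) points downward; the step is expected to be smaller, since the core of compound 3 already tolerates an isopropyl at that place. The estimate for compound 4 is 60 nM, expected to lie between 20 nM and 200 nM.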

Compound 4, half-maximal effective concentration: 14 nM
Compound 4: middle estimate off by 4.3-fold (0.63 log units), on the high side; measured number outside the range, below it.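

Carried from one core to another in this assay, fluoro in place of hydrogen does not give the same result, and the gap between the two steps is larger than repeated measurement would explain: the same change on two cores in this assay, an 8.9-fold higher number (0.95 log units; beyond the scatter) from compound 1 to compound 2 and a 1.5-fold lower number (0.18 log units; within the scatter) from compound 3 to compound 4, 13-fold (1.13 log units) apart, beyond the scatter of two such steps

On the oxadiazole, the change from isopropyl to 1-fluoro-1-methylethyl gives a 1.5-fold lower number from compound 3 to compound 4 (0.18 log units; within the scatter), so the two compounds cannot be told apart; the oxadiazole with fluoro likewise stands level with the unfluorinated carbamate, at a 1.5-fold lower number from compound 1 to compound 4 (0.18 log units; within the scatter), and keeps a clear margin over the fluorinated carbamate, at a 13-fold lower number from compound 2 to compound 4 (1.12 log units; beyond the scatter). This shows that the loss seen on the carbamate cannot be assumed to carry over to the oxadiazole, but with a single pair on each side it does not show what sets the difference, since the group on the carbonyl carbon and the kind of carbon bearing the fluoro change together.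

The compounds shown leave open whether a hydroxyl or a nitrile in place of the fluoro on 1-fluoro-1-methylethyl would also leave the number unchanged. They also leave open whether a longer chain in place of the isopropyl on the oxadiazole would do so, with or without fluoro.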